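Swapping the pyridinyl group on the amide carbonyl

This account rests on a few compounds, and the source may have more. Where it says the series, first, only, none or still open, it means among the compounds named here.

In a functional assay on WM 266-4 cells (Homo sapiens) for antiproliferative activity, read by MTT assay, with a stated time of 24 h (on this read-out higher numbers stand for weaker inhibition of growth and lower numbers for stronger inhibition of growth), compound 2 `COc1ccc(C2=NN(C(=O)c3cccnc3Cl)C(c3ccc(OCc4ccccc4)cc3)C2)cc1` gives 9150 nM, the highest of the two numbers recorded so far. Its nearest neighbour is compound 1 `COc1ccc(C2=NN(C(=O)c3cncc(Br)c3)C(c3ccc(OCc4ccccc4)cc3)C2)cc1`, which in this assay gives 6240 nM; the two values lie within the scatter of each other and cannot be ordered. Compound 3 `COc1ccc(C2=NN(C(=O)c3ccc(C)nc3)C(c3ccc(OCc4ccccc4)cc3)C2)cc1` differs from compound 2 by 6-methylpyridin-3-yl in place of 2-chloropyridin-3-yl on a carbonyl carbon. For the measured compounds named here, only one measured step bears on this change, and it also exchanges one pyridinyl group for another on the same carbonyl carbon: a 1.5-fold higher number from compound 1 to compound 2 (0.17 log units; within the scatter), a step within the scatter. On that basis no step beyond the scatter is expected in this assay in either direction, and the estimated step is a 1.1-fold lower number from compound 2 to compound 3 (0.06 log units; within the scatter). Compound 3 is therefore expected to give about 8000 nM in this assay, with a likely range from 3500 nM to 18000 nM.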

Compound 3, concentration for 50% growth inhibition: 7950 nM
Compound 3: the middle estimate sits 1.0-fold (0.00 log units) above what was measured, within the range that was stated.
By their numbers in this assay, from the lowest: compounds 1, 3 and 2 (each within the scatter of the next).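

In this assay the 6-methylpyridin-3-yl group gives a 1.2-fold lower number from compound 2 to compound 3 (0.06 log units; within the scatter) and also a 1.3-fold higher number from compound 1 to compound 3 (0.11 log units; within the scatter) on the same carbonyl carbon. For the compounds shown here, until now, only two halogen-bearing pyridinyl groups had been compared at this place, and this is the first group in the set with a methyl group and no halogen. Among these three compounds, exchanging the halogen-bearing groups for this one produces no step beyond the scatter, so the three cannot be ordered.

On these data alone, whether the flat picture holds beyond substituted pyridinyl groups, for instance with a phenyl ring, a carboxylic acid or an aliphatic amine on the same carbonyl carbon, remains open. Nothing available here explains why these three groups read alike.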